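The source may report more compounds than this note shows. Statements on the series, on what has been measured and on what is new or still open speak of the compounds shown alone.

In a functional assay on P388 cells (Mus musculus) for cytotoxicity (a higher number here means that more compound is needed for the effect, a lower number that less compound is needed), compound 1 `CC(=O)[C@H]1[C@@H](O)CCC2=C[C@H](O)C[C@H](C)[C@]21C` gives > 5 ug/mL, which is a limit of the assay and not a number. Compound 3 `CC(=O)[C@H]1C(=O)CCC2=C[C@@H](O)C[C@H](C)[C@]21C` gives > 5 ug/mL, also a limit. Compound 2 `C[C@H]1CCC=C2CCC(C(C)(O)CO)=C[C@@]21C`, a differently built molecule, gives a true number of 0.21 ug/mL. Compound 1 therefore stands at the limit of > 5 ug/mL in this assay, at which 2 of the 3 values shown sit. Compound 4 `CC(=O)[C@H]1[C@H](O)CCC2=C[C@@H](O)C[C@H](C)[C@]21C` has the same atoms and bonds as compound 1 and differs only in configuration as drawn: the two compounds have the same atoms and bonds and differ only in configuration as drawn: 2 of 5 stereo elements differ; a stereocentre at a saturated ring carbon is drawn S in compound 1 and R in compound 4; a stereocentre at a saturated ring carbon is drawn R in compound 1 and S in compound 4. Among the measured compounds shown here, no measured pair shows what such a change does here, so no step beyond the usual scatter is expected in this assay, in either direction. The expected step runs a step that the limit leaves unreadable from compound 1 to compound 4. For compound 4, the estimate is 7 ug/mL, with an expected range of 2 ug/mL to 25 ug/mL.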

Compound 4, concentration for half-maximal effect: > 5 ug/mL
Compound 4: no number, only a limit; the forecaster's own chance of this, stated with the estimate: 70%; the middle value is on the limit's open side.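

Among the compounds shown here, compound 1 and compound 4 both give only a limit of the assay and not a number, so no step between them can be read. The compounds shown leave open whether reversing these two stereocentres changes the result in this assay at all.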